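A few compounds are considered here, and "the series" means these few. Any claim that something is new, unique, unknown or untested is made for them only; others in the source may bear on it.

Measured compounds:
- compound 1, `CC(C)COc1ncc(-c2cn(C)c3cc(C(=O)NS(C)(=O)=O)ccc23)cc1Cl`, in an assay for inhibition of sodium channel protein type 9 subunit alpha (Mus musculus), read by patch clamp (a higher number here means a weaker inhibitor, a lower number a stronger inhibitor), compound 1 gives 11 nM
- compound 2, `Cn1cc(-c2ccc(C(F)(F)F)cc2)c2cc(F)c(C(=O)NS(=O)(=O)C3CC3)cc21`, in this assay compound 2 gives 5 nM

Among the measured compounds shown here, of the two numbers so far, compound 2 holds the lower one; compound 1 is the only neighbour, and its number is higher by a gap that lies beyond the usual scatter of repeated runs. For the measured compounds named here, no step between two measured compounds that differ in a single place is available, so nothing within the pair tells how a single substituent change moves the read-out.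

The next compound, compound 3, `Cn1cc(-c2ccc(C(F)F)cc2)c2cc(F)c(C(=O)NS(=O)(=O)C3CC3)cc21`, is compound 2 with one alteration: hydrogen in place of fluoro on a saturated chain carbon bound to an aromatic carbon and two fluorine atoms. Every other part of compound 2, including the cyclopropylsulfonyl amide and the fluoro on the shared core, is retained.

Going by the values given here, no reference step covers this change. The expected effect is a modest rise in the number, at the edge of the scatter rather than a clear loss, since the rest of the structure that carries the potency of compound 2 is unchanged. Compound 3 is therefore expected to give 10 nM, within 3 nM to 35 nM, which amounts to an estimated step of a 2.0-fold higher number from compound 2 to compound 3 (0.30 log units; within the scatter).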

Compound 3, half-maximal inhibitory concentration: 12 nM
Estimate against measurement, compound 3: 1.2-fold (0.08 log units) below; low and high end bracket the measured number.
By their numbers in this assay, from the lowest: compound 2; then compounds 1 and 3 (each within the scatter of the next).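

Going from trifluoromethyl to difluoromethyl in this assay gives a 2.4-fold higher number from compound 2 to compound 3 (0.38 log units; beyond the scatter), the first step in the series that can be read at a single place, and it shows that the read-out responds to the replacement of one fluoro on this saturated chain carbon. The step is modest and lies beyond the usual scatter, so this one fluorine atom accounts for a real but limited part of the number of compound 2, while compound 3 still gives 12 nM with the cyclopropylsulfonyl amide and the shared core unchanged. No measurement at hand bears on why the number moves with this change.

Going by these compounds, the trend at this carbon rests on a single step, so it remains open whether a monofluoromethyl or a methyl group would continue the rise in the number, and whether a nitrile, a chloro or a methoxy group in the place of trifluoromethyl would hold the number of compound 2. On these data alone, it is also open whether the same replacement would give a step of similar size with a methylsulfonyl amide in place of the cyclopropylsulfonyl amide.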